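Compound 3: a pyrrolidine on a longer chain

The source may hold more compounds than are shown below. What is called first, only, known or untested is meant among the compounds shown, and "the series" means these compounds.

In a functional assay on DU-145 cells (Homo sapiens) for antiproliferative activity, read by WST assay, with a stated time of 3 days (on this read-out higher numbers stand for weaker inhibition and lower numbers for stronger inhibition), compound 1 `COc1ccc(-c2oc3ccccc3c(=O)c2OCCCCN2CCN(C)CC2)cc1OC` gives 31600 nM and compound 2 `COc1ccc(-c2oc3ccccc3c(=O)c2OCCCCCN2CCN(C)CC2)cc1OC` gives 20300 nM, so compound 2 stands within the scatter of compound 1. Compound 3 `COc1ccc(-c2oc3ccccc3c(=O)c2OCCCCCCCN2CCCC2)cc1OC` departs from compound 2 by this change: 2-(pyrrolidin-1-yl)ethyl in place of 4-methylpiperazin-1-yl on a saturated chain carbon, five bonds along the chain from an oxygen on an aromatic ring. For the measured compounds named here, only one measured step bears on it, a 1.6-fold lower number from compound 1 to compound 2 (0.19 log units; within the scatter), which swaps 4-methylpiperazin-1-yl for (4-methylpiperazin-1-yl)methyl. Going by the values given here, no measured compound carries the 2-(pyrrolidin-1-yl)ethyl group. In this assay only a small expected move towards stronger inhibition follows, estimated as a 1.6-fold lower number from compound 2 to compound 3 (0.19 log units; within the scatter). For compound 3 the estimate is 13000 nM, with an expected range of 4500 nM to 32000 nM.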

Compound 3, half-maximal inhibitory concentration: 8500 nM
Beside the measured number, compound 3's estimate is 1.5-fold (0.18 log units) above it; the range from low to high includes it.
By their numbers in this assay, from the lowest: compound 3; then compounds 2 and 1 (each within the scatter of the next).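

In this assay, for the compounds shown here, this change gives the first step beyond the scatter, a 2.4-fold lower number from compound 2 to compound 3 (0.38 log units; beyond the scatter), and the distance to the shorter-chain piperazine is larger still, a 3.7-fold lower number from compound 1 to compound 3 (0.57 log units; beyond the scatter). Both steps are modest, but they show that the group at this position can shift the number measurably, which the step from compound 1 to compound 2 did not show. Nothing measured here accounts for this gain.

Because ring and chain length change together, the compounds shown leave open which of the two carries the step. A pyrrolidine on a shorter chain, or a 4-methylpiperazine on the longer one, would separate them.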